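Removing One Trifluoromethyl Group From Compound 2

A few compounds are considered here, and "the series" means these few. Any claim that something is new, unique, unknown or untested is made for them only; others in the source may bear on it.

Compound 2 `O=C(Nc1cccc(-n2cc(-c3ccncc3)c(-c3ccc(Cl)c(O)c3)n2)c1)Nc1cc(C(F)(F)F)cc(C(F)(F)F)c1` is the only one of the three measured compounds that gives a number in a functional assay on CAKI-1 cells (Homo sapiens) for inhibition, read by sulforhodamine B assay, with a stated time of 48 h; on this read-out higher numbers stand for lower toxicity in this test and lower numbers for higher toxicity in this test: compound 2 gives 26500 nM. Compound 1 `COc1cc(-c2nn(-c3cccc(NC(=O)c4ccc(Cl)c(C(F)(F)F)c4)c3)cc2-c2ccncc2)ccc1Cl` reaches only a limit in this assay, > 32500 nM. Compound 3 `COc1cc(-c2nn(-c3cccc(NC(=O)c4ccccc4)c3)cc2-c2ccncc2)ccc1Cl` likewise reaches only a limit in this assay, > 100000 nM. Within the data shown here, the single step between measured compounds that differ in one place, a step that the two limits leave unreadable from compound 1 to compound 3, cannot be read; both of its ends sit at limits, the limit of > 32500 nM in this assay, at which 1 of the 3 values shown sits, and (the limit of > 100000 nM in this assay, at which 1 of the 3 values shown sits), so it gives no size at all.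

Compound 4 `O=C(Nc1cccc(-n2cc(-c3ccncc3)c(-c3ccc(Cl)c(O)c3)n2)c1)Nc1cccc(C(F)(F)F)c1` differs from compound 2 by hydrogen in place of trifluoromethyl on an aromatic carbon. Among the measured compounds shown here, no measured step touches a trifluoromethyl group on this ring, and the one step that was measured yields no readable size. The numbers shown therefore give no ground to expect a step in this assay beyond the scatter in either direction. Compound 4 is accordingly expected to give about 30000 nM, in a range from 10000 nM to 100000 nM. The expected step of a 1.1-fold higher number from compound 2 to compound 4 (0.05 log units; within the scatter) is thus estimated to stay within the scatter, and a result that is only a limit rather than a number is also quite possible for compound 4.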

Compound 4, concentration lethal to 50% of the cells: > 32500 nM
Compound 4 gave a limit, no number (the forecaster's own chance of this, stated with the estimate: 30%); middle value at least 1.0-fold (0.03 log units) from the limit.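

The step from removing this trifluoromethyl group gives the series its first readable size in this assay: an at least 1.2-fold higher number from compound 2 to compound 4 (0.08 log units; that floor lies within the scatter). That size is only a floor, so the change of trifluoromethyl to hydrogen at this place, meta to a trifluoromethyl group that stays, can be said to leave the read-out either within the scatter or well beyond it, and the direction of the floor is towards higher numbers, which stand for lower toxicity in this test. Compound 4 thus joins compound 1 at the same limit, so that the result marks a ceiling of the test rather than a measured value for the new compound: the limit of > 32500 nM in this assay, at which 2 of the 4 values shown sit.

As far as these compounds go, how far the true value of compound 4 lies from that of compound 2 stays open, as does whether the same change would act alike on the other compounds of the set. Nor do the compounds shown tell what an amine, a nitrile or a carboxylic acid on this aromatic carbon would give in place of the trifluoromethyl group.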